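Exchange of the amide substituent in compound 3 to give compound 4

The source may report more compounds than this note shows. Statements on the series, on what has been measured and on what is new or still open speak of the compounds shown alone.

Measured so far:
compound 1 `O=C(CN1CN(c2ccccc2)C2(CCN(C(=O)c3ccc(C4CCCCC4)cc3)CC2)C1=O)N1CCC(CO)CC1` — 1100 nM in an assay on HEK293 cells for displacement of a labelled ligand from NPC1-like intracellular cholesterol transporter 1 (Homo sapiens); on this read-out higher numbers stand for weaker inhibition and lower numbers for stronger inhibition
compound 2 `COC(=O)CCCNC(=O)CN1CN(c2ccccc2)C2(CCN(C(=O)c3ccc(C4CCCCC4)cc3)CC2)C1=O` — 2500 nM in this assay
compound 3 `CC(C)(C)c1ccc(C(=O)N2CCC3(CC2)C(=O)N(CC(=O)N2CCCCC2CCO)CN3c2ccccc2)cc1` — 6100 nM in this assay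

Compound 3 gives the highest number of the three; the gap to compound 2 and the larger gap to compound 1 both lie beyond the scatter, so compound 3 is the weakest inhibitor among the measured compounds. Compound 4 `CCC1CCCN(C(=O)CN2CN(c3ccccc3)C3(CCN(C(=O)c4ccc(C(C)(C)C)cc4)CC3)C2=O)C1` is not yet measured. The change from compound 3 is 3-ethylpiperidin-1-yl in place of 2-(2-hydroxyethyl)piperidin-1-yl on a carbonyl carbon. Within the data shown here, the only measured step at this position is a 2.3-fold higher number from compound 1 to compound 2 (0.36 log units; beyond the scatter); it exchanges groups on the same carbonyl carbon, but both groups carry oxygen, and compound 1 and compound 2 carry cyclohexyl where compound 3 carries tert-butyl, so it bears on the present step only loosely. It shows that changes at this carbonyl carbon move the number modestly. Among the measured compounds shown here, no measured step removes the hydroxyl outright, so the direction is open; a modest step in either sense is expected, leaning slightly toward a lower number. Compound 4 is estimated at 4000 nM, range 1500 nM to 11000 nM, meaning an expected step of a 1.5-fold lower number from compound 3 to compound 4 (0.18 log units; within the scatter).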

Compound 4, half-maximal inhibitory concentration: 3900 nM
The estimate for compound 4 lay 1.0-fold (0.01 log units) above the measured number; low and high end bracket the measured number.
By their numbers in this assay, from the lowest: compound 1; then compounds 2, 4 and 3 (each within the scatter of the next, the first and the last beyond it).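

In this assay, replacing 2-(2-hydroxyethyl)piperidin-1-yl with 3-ethylpiperidin-1-yl on the carbonyl carbon gives a 1.6-fold lower number from compound 3 to compound 4 (0.19 log units; within the scatter) and stays within the scatter. Unlike the step between compound 1 and compound 2, where both groups carry oxygen, this pair shows that a substituent with no oxygen, hydrogen-bond donor or acceptor can sit here without a step beyond the scatter. Nothing available explains this result.

The exchange changes both the chain and its place on the piperidine, so the pair cannot separate the loss of the hydroxyl from that shift. Open questions are how 2-ethylpiperidin-1-yl and 3-(2-hydroxyethyl)piperidin-1-yl would compare, and whether a carboxylic acid or primary amine at the end of the chain would give a larger step.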